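The source may hold more compounds than are shown below. What is called first, only, known or untested is meant among the compounds shown, and "the series" means these compounds.

Compound 1 `O=C1COc2ccccc2N1CCCn1cc(-c2ccccc2)nn1`: 94000 nM
Compound 2 `Cc1ccc(-c2cn(CCCN3C(=O)COc4ccccc43)nn2)cc1`: > 100000 nM (a limit, not a number)
Compound 3 `COc1ccc(-c2cn(CCCN3C(=O)COc4ccccc43)nn2)cc1`: 15700 nM

Going by the values given here, in a functional assay on MiaPaCa cells (Homo sapiens) for antiproliferative activity, read by sulforhodamine B assay, with a stated time of 48 h (on this read-out lower numbers stand for stronger inhibition of growth and higher numbers for weaker inhibition of growth), compound 3 gives 15700 nM, the lowest of the actual numbers so far. Compound 2 gives only a limit of the assay, > 100000 nM.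

The measured steps all swap a small group on an aromatic carbon. Methoxy in place of hydrogen gives a 6.0-fold lower number from compound 1 to compound 3 (0.78 log units; beyond the scatter), and methoxy in place of methyl gives an at least 6.3-fold lower number from compound 2 to compound 3 (0.80 log units; beyond the scatter). Methyl in place of hydrogen gives an at least 1.0-fold higher number from compound 1 to compound 2 (0.02 log units; that floor lies within the scatter).

The next compound, compound 4 `CCCCCCc1cn(CCCN2C(=O)COc3ccccc32)nn1`, changes much more: hexyl in place of 4-methoxyphenyl on an aromatic carbon. This is hexyl in place of 4-methoxyphenyl on an aromatic carbon. Among the compounds with values here, no measured step replaces this whole group, so the earlier steps offer only a loose guide.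

Still, the methoxy that accompanied a 6.0-fold lower number from compound 1 to compound 3 (0.78 log units; beyond the scatter) leaves in this change, which suggests a drift back towards compound 1 at 94000 nM. The expected change is a 3.2-fold higher number from compound 3 to compound 4 (0.50 log units; beyond the scatter), towards weaker inhibition of growth, beyond the scatter but uncertain in size. A reading at the limit also remains possible: the limit of > 100000 nM in this assay, at which 1 of the 3 values shown sits. For compound 4 the estimated value is 50000 nM, with an expected range of 15000 nM to 100000 nM.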

Compound 4, concentration for 50% growth inhibition: 150 nM
Compound 4: the middle estimate sits 330-fold (2.52 log units) above what was measured, and the stated range ends above it.
By their numbers in this assay, from the lowest: compound 4; then compound 3; then compound 1. At a limit, above all of these: compound 2.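

In this assay, the group on this aromatic carbon of the five-membered aromatic ring turns out to matter far more than the small swaps on the phenyl ring had suggested: a hexyl chain with no ring gives a 100-fold lower number from compound 3 to compound 4 (2.02 log units; beyond the scatter), and against the plain phenyl it gives a 630-fold lower number from compound 1 to compound 4 (2.80 log units; beyond the scatter), both much larger than a 6.0-fold lower number from compound 1 to compound 3 (0.78 log units; beyond the scatter). So a six-membered aromatic ring is not needed at this position for growth inhibition in this series, and among the compounds shown, the one without it gives the lowest number, with the step of an at least 660-fold lower number from compound 2 to compound 4 (2.82 log units; beyond the scatter) serving only as a floor. Compound 2 is a limit and not a number: the limit of > 100000 nM in this assay, at which 1 of the 4 values shown sits.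

With hexyl as the only chain shown, the compounds leave open whether a shorter butyl chain or a longer octyl chain would give a lower or higher number, and whether a ring such as cyclohexyl would do as well as the open chain. They also leave open whether an amine or a carboxylic acid at the end of the hexyl chain would keep the low number of compound 4.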